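Methoxy for chloro on a compound at the limit

The source may report more compounds than this note shows. Statements on the series, on what has been measured and on what is new or still open speak of the compounds shown alone.

Measured in a toxicity assay on THP-1 cells (Homo sapiens) for cytotoxicity, read by MTT assay; a lower number here means a stronger inhibitor of growth, a higher number a weaker inhibitor of growth:
Compound 1 `COc1ccc(-c2csc(N/N=C(\C)c3sc(C)nc3C)n2)cc1`: > 100 ug/mL
Compound 2 `C/C(=N\Nc1nc(-c2ccc(F)cc2)cs1)c1sc(-c2ccccc2)nc1C`: > 100 ug/mL
Compound 3 `C/C(=N\Nc1nc(-c2ccc(Cl)cc2)cs1)c1sc(-c2ccccc2)nc1C`: > 100 ug/mL

Within the data shown here, the whole series so far is summed up by the limit of > 100 ug/mL in this assay, at which 3 of the 3 values shown sit. Compound 3 stands there too, and its > 100 ug/mL is a limit, not a number.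

Compound 4 `COc1ccc(-c2csc(N/N=C(\C)c3sc(-c4ccccc4)nc3C)n2)cc1` keeps the core of compound 3 and changes 4-chlorophenyl to 4-methoxyphenyl, with methoxy in place of chloro on an aromatic carbon, para to a large group: methoxy in place of chloro on an aromatic carbon.

Among the measured compounds shown here, the only measured step at this place is a step that the two limits leave unreadable from compound 2 to compound 3, so it offers no size to carry over. Compound 1 also carries the 4-methoxyphenyl group, and its > 100 ug/mL is likewise a limit. The data therefore give no ground to expect a step beyond the scatter in this assay, in either direction. The expected change is a step that the limit leaves unreadable from compound 3 to compound 4. For compound 4 the estimated value is 150 ug/mL, with an expected range of 70 ug/mL to 400 ug/mL.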

Compound 4, concentration for 50% growth inhibition: > 100 ug/mL
Compound 4 ended at the assay's limit; the forecaster's own chance of this, stated with the estimate: 85%; the middle value does not contradict the limit.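

No step can be read from compound 1, compound 2 or compound 3 to compound 4, because all four stand at one limit: the limit of > 100 ug/mL in this assay, at which 4 of the 4 values shown sit.

The compounds shown leave open how strongly any of them inhibits growth in this assay, and whether exchanging chloro, fluoro, methoxy, methyl or phenyl makes any difference there.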